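Inverting Configuration in a Cell-Based Inhibition Assay

The source may report more compounds than this note shows. Statements on the series, on what has been measured and on what is new or still open speak of the compounds shown alone.

Measured compounds:
compound 1 `CC(C)(CO)[C@H](O)C(=O)N/C=C/C(=O)OCc1ccccc1`: -6%
compound 2 `COC(=O)/C=C/NC(=O)[C@@H](O)C(C)(C)CO`: -2%

In an ADME assay on HEK293 cells (Homo sapiens) for inhibition, read by CellTiter-Glo, with a stated time of 96 h, tested at 100 uM (a higher number here means more inhibition at the concentration tested (going by the name of the read-out), a lower number less inhibition), compound 1 gives -6%, and in this assay compound 2 gives -2%; the two numbers sit within the scatter of each other, with a number 4 percentage points higher from compound 1 to compound 2 (within the scatter). Compound 3 `CC(C)(CO)[C@@H](O)C(=O)N/C=C\C(=O)OCc1ccccc1` differs from compound 1 only in configuration: the two compounds have the same atoms and bonds and differ only in configuration as drawn: 2 of 2 stereo elements differ; a stereocentre at a saturated chain carbon is drawn S in compound 1 and R in compound 3; a double bond is drawn E in compound 1 and Z in compound 3. Among the compounds with values here, no measured step involves a change of configuration, so none bears directly on this one; the single step measured stays within the scatter. Compound 3 is therefore expected to give -4% (range -18% to 10%), an estimated step of a number 2 percentage points higher from compound 1 to compound 3 (within the scatter) that is not expected to exceed the scatter.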

Compound 3, a percentage reported as inhibition, at one concentration (the size of the read-out at that concentration, not a potency): 7%
The estimate for compound 3 lay 11 percentage points below the measured number, and the stated range covers the measured number.
By their numbers in this assay, from the lowest: compounds 1, 2 and 3 (each within the scatter of the next, the first and the last beyond it).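

In this assay, a change of configuration alone gives a step that the hydrogen in place of phenyl change did not: a number 13 percentage points higher from compound 1 to compound 3 (beyond the scatter), a modest one. No atom or bond changes, so the step can be tied only to configuration: the fact that compounds 1 and 3 differ only in the configuration as drawn. The stereocentre at the saturated chain carbon and the double bond change together, so the compounds shown leave open which of the two carries the step, or whether both are needed. They also leave open how a carboxylic acid in place of the ester would read at either configuration.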